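Swapping fluoro for bromo on compound 3

The compounds below may be only part of what the source reports. "The series", "measured", "known", "first", "only" and "open" are said of these compounds alone.

- compound 1 `Cc1ccc(C(C)C)c(OCCSC(=S)N[C@H]2CCOC2=O)c1` gives > 64000 nM (a limit of the assay, not a number)
- compound 2 `O=C1OCC[C@@H]1NC(=S)SCCOc1ccc([N+](=O)[O-])cc1` gives 31000 nM
- compound 3 `O=C(COc1ccc(C(=O)/C=C/c2ccc(F)cc2)cc1)N[C@H]1CCOC1=O` gives 18800 nM

In a functional assay on DU-145 cells (Homo sapiens) for antiproliferative activity, read by MTT assay, with a stated time of 72 h (a lower number here means a stronger inhibitor, a higher number a weaker inhibitor), compound 3 at 18800 nM and compound 2 at 31000 nM lie within the usual scatter of each other. Compound 4 `O=C(COc1ccc(C(=O)/C=C/c2ccc(Br)cc2)cc1)N[C@H]1CCOC1=O` differs from compound 3 in one place: bromo in place of fluoro on an aromatic carbon puts bromo in place of fluoro on an aromatic carbon, para to a large group. For the measured compounds named here, no measured pair shows this change, so no step beyond the scatter is expected in this assay and neither direction is favoured. The expected step of a 1.2-fold lower number from compound 3 to compound 4 (0.07 log units; within the scatter) is therefore small. For compound 4 the expected value is 16000 nM with an estimated range from 6000 nM to 42000 nM in this forecast.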

Compound 4, half-maximal inhibitory concentration: 51700 nM
Estimate against measurement, compound 4: 3.2-fold (0.51 log units) below, and the stated range ends below it.
By their numbers in this assay, from the lowest: compounds 3, 2 and 4 (each within the scatter of the next, the first and the last beyond it). At a limit, above all of these: compound 1.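

For the compounds shown here, changing only the halogen on the 4-fluorophenyl end gives a 2.8-fold higher number from compound 3 to compound 4 (0.44 log units; beyond the scatter) in this assay, and this is the first comparison here between compounds that differ in one place. This aromatic carbon is therefore not indifferent to what it carries, and for this pair, fluoro gives the lower number, although a single pair cannot show why. Compound 1 remains a limit, not a number: the limit of > 64000 nM in this assay, at which 1 of the 4 values shown sits.

From the compounds shown here alone, whether chloro or methyl on this carbon would give a number nearer that of compound 3 or compound 4 stays open. So does the effect of an amine or a carboxylic acid there.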